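From bromo to naphthalen-2-yl on the shared core

This account rests on a few compounds, and the source may have more. Where it says the series, first, only, none or still open, it means among the compounds named here.

compound 1 `O=C1OC(O)C(c2cccc(-c3ccc4ccccc4c3)c2)=C1Br`: "not determined" (no result reported)
compound 2 `CCCCc1ccc(C2=C(c3ccc(-c4ccc(CCCC)cc4)cc3)C(O)OC2=O)cc1`: 4590 nM

Measurements in this series come from a functional assay on RAW264.7 cells (Mus musculus) for inhibition, read by immunoassay, with a stated time of 20 h (on this read-out higher numbers stand for weaker inhibition and lower numbers for stronger inhibition), and so far yield a single number. Compound 1 has no place on that scale: its entry reads "not determined" (no result reported) and offers no value to start from. Among the measured compounds shown here, compound 2 gives 4590 nM as the only reading available. Compound 3 `O=C1OC(O)C(c2cccc(-c3ccc4ccccc4c3)c2)=C1c1ccc2ccccc2c1` follows from compound 1 through naphthalen-2-yl in place of bromo on a double-bonded ring carbon with naphthalen-2-yl in place of bromo on a double-bonded ring carbon. For the measured compounds named here, no step between measured compounds exists, so the size of this change in this assay cannot be read from the data, and compound 1 supplies no direction. The working expectation is that compound 3 falls close to compound 2 at 4590 nM with no step beyond the scatter, a weak anchor resting on one reading. The estimated half-maximal inhibitory concentration for compound 3 is 3500 nM with an expected range of 1000 nM to 12000 nM in this assay.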

Compound 3, half-maximal inhibitory concentration: 840 nM
Beside the measured number, compound 3's estimate is 4.2-fold (0.62 log units) above it, outside the stated range (below it).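

In this assay compound 1 gives "not determined" (no result reported) and compound 3 differs from compound 2 in more than one place, so no step can be read among compound 1, compound 2 and compound 3. The compounds shown leave open how naphthalen-2-yl in place of bromo changes inhibition on the shared core. Nothing available bears on a cause for the result.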